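Removing the para isobutyl group from the sulfonamide series

The source may hold more compounds than are shown below. What is called first, only, known or untested is meant among the compounds shown, and "the series" means these compounds.

Compound 1 `CC(C)Cc1ccc(NS(=O)(=O)c2ccc(N3CCNC3=O)cc2)cc1` carries an isobutyl group on the aniline ring. In a functional assay on MCF7 cells (Homo sapiens) for antiproliferative activity, read by sulforhodamine B assay, with a stated time of 48 h (a lower number here means a stronger inhibitor, a higher number a weaker inhibitor), compound 1 gives only a limit, > 1000 nM, not a number. Compound 2 `CCCCCCOc1ccc(NS(=O)(=O)c2ccc(N3CCNC3=O)cc2)cc1` likewise gives only a limit in this assay, > 1000 nM. The step that the two limits leave unreadable from compound 1 to compound 2 therefore cannot be read. For the measured compounds named here, compound 3 `Cc1cc(C)cc(NS(=O)(=O)c2ccc(N3CCNC3=O)cc2)c1`, with two methyl groups on the same ring, gives 100 nM in this assay, the one number in the set; the other two values sit at the limit of > 1000 nM in this assay, at which 2 of the 3 values shown sit.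

Compound 4 `O=C1NCCN1c1ccc(S(=O)(=O)Nc2ccccc2)cc1` is reached from compound 1 by the change (hydrogen in place of isobutyl on an aromatic carbon), at a place that is para to a large group. Going by the values given here, no measured step bears directly on it: the only step, from compound 1 to compound 2, is unreadable, and compound 3 differs at other places. What the values show is that the two compounds with a long group at that position are beyond the limit, while the small-substituted compound 3 is not.

Compound 4 is expected to gain, by a step of an at least 2.0-fold lower number from compound 1 to compound 4 (0.30 log units; that floor lies within the scatter), so that its value in this assay is estimated at 500 nM within 100 nM to 3000 nM, with a real chance that it too reaches only a limit.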

Compound 4, half-maximal inhibitory concentration: 470 nM
Compound 4: the middle estimate sits 1.1-fold (0.03 log units) above what was measured; the measured number falls inside the stated range.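

In this assay, this position now gives readable steps: taking away the isobutyl group yields an at least 2.1-fold lower number from compound 1 to compound 4 (0.32 log units; beyond the scatter), and taking away the hexyloxy group yields an at least 2.1-fold lower number from compound 2 to compound 4 (0.32 log units; beyond the scatter). Hydrogen here does not by itself match the best number in the set, since phenyl in place of 3,5-dimethylphenyl on the sulfonamide nitrogen gives a 4.7-fold higher number from compound 3 to compound 4 (0.67 log units; beyond the scatter). Both gains are floors, not sizes, as each starts from a limit: the limit of > 1000 nM in this assay, at which 2 of the 4 values shown sit.

As far as these compounds go, the true size of those two gains remains open. Also open, from the compounds shown here alone, is how a small group at this position, such as a methyl group, a methoxy group or an amine, would compare with the hydrogen of compound 4 in this assay.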